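Swapping Bromo for Methyl in Two Related Inhibitors

This account rests on a few compounds, and the source may have more. Where it says the series, first, only, none or still open, it means among the compounds named here.

Of the compounds shown here, three have been tested in an assay on microsomes for inhibition of Amine oxidase [flavin-containing] B (Homo sapiens), read by fluorescence and spectrophotometry, with a stated time of 20 min; a higher number here means a weaker inhibitor, a lower number a stronger inhibitor. Compound 1 `O=c1ccoc2ccc(OCc3cccc(Br)c3)cc12` gives 2 nM, and compound 2 `O=c1ccoc2ccc(OCc3ccc(Br)cc3)cc12` gives 3.3 nM; the difference between these two cores is not broken down here, and their two values lie within the usual scatter of each other. Compound 3 `Cc1cccc(COc2ccc3occc(=O)c3c2)c1` gives 19 nM in this assay.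

From compound 1 to compound 3 the change is methyl in place of bromo on an aromatic carbon, and it produced a 9.5-fold higher number from compound 1 to compound 3 (0.98 log units; beyond the scatter). Compound 4 `Cc1ccc(COc2ccc3occc(=O)c3c2)cc1`, not yet measured, carries the change methyl in place of bromo on an aromatic carbon relative to compound 2. The two changes are the same kind of change, not the same: in compound 3 the methyl sits meta to a large group, while in compound 4 it sits para to a large group.

For compound 4 the expected step is a 9.1-fold higher number from compound 2 to compound 4 (0.96 log units; beyond the scatter) in this assay, resting on the step seen from compound 1 to compound 3, a 9.5-fold higher number from compound 1 to compound 3 (0.98 log units; beyond the scatter), with added uncertainty from the different place. Compound 4 is therefore estimated at 30 nM, in a range from 8 nM to 110 nM.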

Compound 4, half-maximal inhibitory concentration: 6 nM
Beside the measured number, compound 4's estimate is 5.0-fold (0.70 log units) above it, outside the stated range (below it).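

The swap of bromo for methyl gives a 1.8-fold higher number from compound 2 to compound 4 (0.26 log units; within the scatter) in this assay and so stays within the usual scatter, while the same swap on the other core gave a clearly larger step: the same change on two cores in this assay, a 9.5-fold higher number (0.98 log units; beyond the scatter) from compound 1 to compound 3 and a 1.8-fold higher number (0.26 log units; within the scatter) from compound 2 to compound 4, 5.2-fold (0.72 log units) apart, beyond the scatter of two such steps

This shows that, in this series, the size of the step measured on one core cannot simply be carried to another, even when the same two groups are exchanged. It does not show what sets the two steps apart, since the pairs differ in their cores and the change sits para to a large group only in the second pair, and two pairs cannot support a general rule.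

Still open, on these data alone, is whether other groups in the same place, such as chloro or methoxy, would give steps that also differ between the two cores. As far as these compounds go, whether an amine or a longer chain there would follow either step also remains open.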